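Nitroethenyl in place of hydroxylamine on a polyene chain

The compounds below may be only part of what the source reports. "The series", "measured", "known", "first", "only" and "open" are said of these compounds alone.

Compound 1 `CC(C)=CCC/C(C)=C/CC/C(C)=C/CC/C=C(\C)CC/C=C(\C)CCCC(O)C[N+](=O)[O-]`: 270000 nM
Compound 2 `CC(C)=CCC/C(C)=C/CC/C(C)=C/CC/C=C(\C)CC/C=C(\C)CCCN(C)O`: 13000 nM

Two compounds were measured in an assay on microsomes from liver (Sus scrofa) for inhibition of squalene monooxygenase (Homo sapiens); on this read-out lower numbers stand for stronger inhibition and higher numbers for weaker inhibition. Compound 1 gives 270000 nM, while compound 2 gives 13000 nM, which is the lowest of the two numbers; the step of a 21-fold lower number from compound 1 to compound 2 (1.32 log units; beyond the scatter) lies well beyond the scatter. Compound 3 `CC(C)=CCC/C(C)=C/CC/C(C)=C/CC/C=C(\C)CC/C=C(\C)CC/C=C/[N+](=O)[O-]` has not been measured. It differs from compound 2 by 2-nitroethenyl in place of (hydroxy(methyl)amino)methyl on a saturated chain carbon, two bonds along the chain from a double-bonded chain carbon. For the measured compounds named here, the only step that bears on this change is a 21-fold lower number from compound 1 to compound 2 (1.32 log units; beyond the scatter), which showed that exchanging a nitro-bearing chain end for a hydroxy(methyl)amino group lowered the number strongly. Compound 3 returns a nitro-bearing end, though without the hydroxy group of compound 1, so the expected direction is back toward a higher number, with an estimated step of a 7.7-fold higher number from compound 2 to compound 3 (0.89 log units; beyond the scatter). Compound 3 is therefore expected at about 100000 nM, within the range 20000 nM to 400000 nM.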

Compound 3, half-maximal inhibitory concentration: > 400000 nM
Compound 3: only a limit was reported; the forecaster's own chance of this, stated with the estimate: 10%; middle value at least 4.0-fold (0.60 log units) away from the limit.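

In this assay compound 3 gives > 400000 nM, which is a limit and not a number: the limit of > 400000 nM in this assay, at which 1 of the 3 values shown sits. Even so, the change reads as an at least 30-fold higher number from compound 2 to compound 3 (1.48 log units; beyond the scatter) with 2-nitroethenyl in place of (hydroxy(methyl)amino)methyl on a saturated chain carbon, two bonds along the chain from a double-bonded chain carbon, so this change does not keep the level seen with compound 2. The other step reads as an at least 1.4-fold higher number from compound 1 to compound 3 (0.17 log units; that floor lies within the scatter) and gives only a floor, so these two nitro-bearing ends cannot be placed in order.

The compounds shown leave open whether the hydroxy, the methyl or the nitrogen of the hydroxy(methyl)amino group carries the difference, which a plain amine or a hydroxylamine without the methyl would separate. They also leave open how a carboxylic acid or a longer chain at this end would read.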